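The source may hold more compounds than are shown below. What is called first, only, known or untested is meant among the compounds shown, and "the series" means these compounds.

Of the compounds shown here, three built on one shared core have been tested in an assay on isolated protein for inhibition of aldehyde dehydrogenase 1A1 (Homo sapiens), read by spectrophotometry, tested at 10 uM; a lower number here means less inhibition, a higher number more inhibition at the concentration tested (going by the name of the read-out). Compound 1 `Cc1cccc(Cn2c(CN3CCN(C(=O)c4ccc(C(C)C)cc4)CC3)nc3ccccc32)c1` carries an isopropyl on an aromatic carbon and gives 67.6%. Compound 2 `Cc1ccc(C(=O)N2CCN(Cc3nc4ccccc4n3Cc3cccc(C)c3)CC2)cc1` carries a methyl at that carbon and gives 64.9%. Compound 3 `COc1ccc(C(=O)N2CCN(Cc3nc4ccccc4n3Cc3cccc(C)c3)CC2)cc1` carries a methoxy there and gives 55.5%, the lowest of the three numbers; its gap to compound 2 lies within the scatter, while its gap to compound 1 lies beyond it.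

Among the compounds with values here, compound 4 `Cc1cccc(Cn2c(CN3CCN(C(=O)c4ccc(Br)cc4)CC3)nc3ccccc32)c1` has not yet been measured. bromo in place of methoxy on an aromatic carbon No measured step swaps methoxy for bromo, so the nearest guides are the two steps that bring methoxy in: a number 12.1 percentage points lower from compound 1 to compound 3 (beyond the scatter) and a number 9.4 percentage points lower from compound 2 to compound 3 (within the scatter). Read in reverse, taking methoxy away in favour of a carbon group raised the number by a modest amount at most. Bromo is neither of those groups, and nothing measured shows how it behaves on this core. The expectation for compound 4 is therefore a small rise, roughly back to the level of compound 2, with a step of a number 7.5 percentage points higher from compound 3 to compound 4 (within the scatter). The estimate for compound 4 is 63%, between 48% and 78%.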

Compound 4, a percentage reported as inhibition, at one concentration (the size of the read-out at that concentration, not a potency): 25.8%
Estimate against measurement, compound 4: 37.2 percentage points above, and the stated range ends above it.
By their numbers in this assay, from the lowest: compound 4; then compounds 3, 2 and 1 (each within the scatter of the next, the first and the last beyond it).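

In this assay, putting bromo on this aromatic carbon, para to a large group, gives a number 29.7 percentage points lower from compound 3 to compound 4 (beyond the scatter), and the comparisons with the two carbon groups are larger still, at a number 39.1 percentage points lower from compound 2 to compound 4 (beyond the scatter) and a number 41.8 percentage points lower from compound 1 to compound 4 (beyond the scatter). The earlier compounds shown here made this position look fairly forgiving, with the largest step among them only modest, whereas compound 4 shows that a single substituent change here can reduce the inhibition seen at the tested concentration much more sharply. Nothing available explains why bromo behaves so differently from methoxy, methyl and isopropyl at this carbon.

With bromo as the only halogen among these compounds, it remains open whether the fall belongs to bromo alone or extends to halogens more generally, a question that chloro or fluoro at the same carbon would help answer. An amine or a carboxylic acid at this carbon would show how groups of quite different character fare here, and bromo at another carbon of the same ring would show whether the fall depends on this exact placement.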